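The compounds below may be only part of what the source reports. "The series", "measured", "known", "first", "only" and "open" are said of these compounds alone.

Measured in a functional assay (aorta) with Rattus norvegicus as the target; a higher number here means that more compound is needed for the effect, a lower number that less compound is needed:
- compound 1 `C/N=C(/NC)Nc1nc(-c2ccc(OC)cc2)c(-c2ccc(OC)cc2)s1`: 2.4 uM
- compound 2 `COc1ccc(-c2nc(C(=O)N=C(N)N)sc2-c2ccc(OC)cc2)cc1`: > 100 uM (a limit)
- compound 3 `CCOC(=O)/C(C#N)=C/c1nc(-c2ccc(OC)cc2)c(-c2ccc(OC)cc2)s1`: > 100 uM (a limit)

Compound 3 has no number of its own and stands at the limit of > 100 uM in this assay, at which 2 of the 3 values shown sit. Compound 4 `COc1ccc(-c2nc(C3=CCN(C)CC3)sc2-c2ccc(OC)cc2)cc1` has not yet been measured. It loses the 2-cyano-2-(ethoxycarbonyl)ethenyl group of compound 3 and carries, at the same place, one six-membered non-aromatic ring with 1 hetero atom: a group of 7 heavy atoms (6 carbon, 1 nitrogen; one six-membered non-aromatic ring with 1 hetero atom) in place of a group of 9 heavy atoms (6 carbon, 1 nitrogen, 2 oxygen; no ring), on an aromatic carbon.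

Within the data shown here, no measured step makes this exact change. The closest evidence is an at least 41-fold higher number from compound 1 to compound 3 (1.61 log units; beyond the scatter), together with an at least 41-fold higher number from compound 1 to compound 2 (1.61 log units; beyond the scatter). Both steps are large and show that a change at this place can move the read-out strongly. The step that the two limits leave unreadable from compound 2 to compound 3 adds nothing. Only compound 1 gives a number, 2.4 uM.

A move to a lower number in this assay is expected, though weakly, and compound 4 may also stay at the limit. The expected step is an at least 3.3-fold lower number from compound 3 to compound 4 (0.52 log units; beyond the scatter). Compound 4 is estimated at 30 uM, with an expected range of 4 uM to 150 uM.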

Compound 4, concentration for half-maximal effect: 5.9 uM
Compound 4: the middle estimate sits 5.1-fold (0.71 log units) above what was measured; low and high end bracket the measured number.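

Compound 2 and compound 3 each carry only a limit, not a number: the limit of > 100 uM in this assay, at which 2 of the 4 values shown sit. In this assay, the six-membered non-aromatic ring with 1 hetero atom is a second group at this aromatic carbon, next to the ring nitrogen and the ring sulfur, that gives a real number, with an at least 16-fold lower number from compound 3 to compound 4 (1.22 log units; beyond the scatter) and an at least 16-fold lower number from compound 2 to compound 4 (1.22 log units; beyond the scatter). Measured against the group of compound 1, the ring gives a 2.5-fold higher number from compound 1 to compound 4 (0.39 log units; beyond the scatter), so the group of compound 1 is not the only one shown here that stays clear of the limit, although it keeps a modest edge.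

The compounds shown leave open what a saturated piperidine ring or an all-carbon cyclohexenyl ring would give at this place. They also leave open what an open-chain amine would give there.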